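A Smaller Amide Tail on a Cholesterol-Transporter Ligand

The source may report more compounds than this note shows. Statements on the series, on what has been measured and on what is new or still open speak of the compounds shown alone.

Compound 1 `CC(C)(C)c1ccc(C(=O)N2CCC3(CC2)C(=O)N(CC(=O)N2CCC(CCO)CC2)CN3c2ccccc2)cc1` was tested in an assay on HEK293 cells for displacement of a labelled ligand from NPC1-like intracellular cholesterol transporter 1 (Homo sapiens) (on this read-out higher numbers stand for weaker inhibition and lower numbers for stronger inhibition), where compound 1 gives 2600 nM. Among the three measured compounds this is the second highest number. Compound 2 `CS(=O)(=O)NCCNC(=O)CN1CN(c2ccccc2)C2(CCN(C(=O)c3ccc(C4CCCCC4)cc3)CC2)C1=O` gives 2100 nM in this assay, and compound 3 `CC(C)(C)OC(=O)NCC1CCN(C(=O)CN2CN(c3ccccc3)C3(CCN(C(=O)c4ccc(C(C)(C)C)cc4)CC3)C2=O)CC1` gives 4200 nM; all three lie within the usual scatter of one another. For the measured compounds named here, the only measured step that touches the same part of the molecule is a 1.6-fold higher number from compound 1 to compound 3 (0.21 log units; within the scatter). Compound 4 `CC(C)(C)c1ccc(C(=O)N2CCC3(CC2)C(=O)N(CC(=O)N2CCNCC2)CN3c2ccccc2)cc1` differs from compound 1 in that same tail: piperazin-1-yl in place of 4-(2-hydroxyethyl)piperidin-1-yl on a carbonyl carbon. The earlier step swapped groups on this tail without moving the number, and the new ring keeps one hydrogen-bond donor and one acceptor. Compound 4 is therefore expected to show a 1.2-fold higher number from compound 1 to compound 4 (0.06 log units; within the scatter), nothing beyond the scatter, with an estimate of 3000 nM and a range from 1000 nM to 9000 nM.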

Compound 4, half-maximal inhibitory concentration: 22000 nM
Compound 4: middle estimate off by 7.3-fold (0.87 log units), on the low side, outside the stated range (above it).
By their numbers in this assay, from the lowest: compounds 2, 1 and 3 (each within the scatter of the next); then compound 4.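

For the compounds shown here, replacing 4-(2-hydroxyethyl)piperidin-1-yl with piperazin-1-yl on this carbonyl carbon gives an 8.5-fold higher number from compound 1 to compound 4 (0.93 log units; beyond the scatter) in this assay, the first step on this tail to go beyond the scatter. The two groups have the same hydrogen-bond donor and acceptor counts, so those counts alone do not settle the result here. Nothing available explains this step.

On these data alone, it remains open whether the result follows the loss of the 2-hydroxyethyl chain or the second ring nitrogen. A plain piperidin-1-yl or a 4-(2-hydroxyethyl)piperazin-1-yl on the same carbonyl carbon would separate the two.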